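A few compounds are considered here, and "the series" means these few. Any claim that something is new, unique, unknown or untested is made for them only; others in the source may bear on it.

Measured in a functional assay on DU-145 cells (Homo sapiens) for antiproliferative activity, read by MTT assay, with a stated time of 48 h; a higher number here means a weaker inhibitor, a lower number a stronger inhibitor:
- compound 1 `C/C(=C\CC/C(C)=C/CC[C@@H]1[C@@]2(C)CCC(=O)C(C)(C)[C@H]2CC[C@@]1(C)O)CC/C=C(\C)C(=O)OCc1cn(-c2cccc(Cl)c2)nn1`: 103000 nM
- compound 2 `C/C(=C\CC/C(C)=C/CC[C@@H]1[C@@]2(C)CCC(=O)C(C)(C)[C@H]2CC[C@@]1(C)O)CC/C=C(\C)C(=O)OCc1cn(-c2ccc(C)cc2)nn1`: a limit of the assay, > 150000 nM
- compound 3 `C/C(=C\CC/C(C)=C/CC[C@@H]1[C@@]2(C)CCC(=O)C(C)(C)[C@H]2CC[C@@]1(C)O)CC/C=C(\C)C(=O)OCc1cn(-c2ccccc2Br)nn1`: a limit of the assay, > 150000 nM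

Compound 3 stands only at a limit of this assay, and one further value shown is a limit as well; two of the three values sit at the limit of > 150000 nM in this assay, at which 2 of the 3 values shown sit. The step from compound 1 is an at least 1.4-fold higher number from compound 1 to compound 3 (0.16 log units; that floor lies within the scatter), with 2-bromophenyl in place of 3-chlorophenyl on an aromatic nitrogen. The step that the two limits leave unreadable from compound 2 to compound 3 cannot be read, since both ends are limits.

Compound 4 `C/C(=C\CC/C(C)=C/CC[C@@H]1[C@@]2(C)CCC(=O)C(C)(C)[C@H]2CC[C@@]1(C)O)CC/C=C(\C)C(=O)OCc1cn(-c2cccc([N+](=O)[O-])c2)nn1` differs from compound 3 as follows: 3-nitrophenyl in place of 2-bromophenyl on an aromatic nitrogen. Among the measured compounds shown here, the steps that bear on it are an at least 1.4-fold higher number from compound 1 to compound 2 (0.16 log units; that floor lies within the scatter) and an at least 1.4-fold higher number from compound 1 to compound 3 (0.16 log units; that floor lies within the scatter), both at least the floor noted and both leading to limits. For the measured compounds named here, the only numeric value, that of compound 1, lies close to the limit. Compound 4 is therefore expected to give a number near that limit, with the step of an at least 1.2-fold lower number from compound 3 to compound 4 (0.09 log units; that floor lies within the scatter) expected to stay within the scatter. The estimate for compound 4 in this assay is 120000 nM, ranging from 60000 nM to 250000 nM.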

Compound 4, half-maximal inhibitory concentration: > 150000 nM
Compound 4 ended at the assay's limit (the forecaster's own chance of this, stated with the estimate: 55%); middle value at least 1.2-fold (0.09 log units) away from the limit.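

Compound 4 also stands at a limit in this assay, so 3-nitrophenyl on the aromatic nitrogen joins 4-methylphenyl and 2-bromophenyl there: the limit of > 150000 nM in this assay, at which 3 of the 4 values shown sit. Among the compounds shown here, with nitro in place of chloro on an aromatic carbon, the one pair that keeps a numeric end gives an at least 1.4-fold higher number from compound 1 to compound 4 (0.16 log units; that floor lies within the scatter), so even this closest comparison shows no difference beyond the scatter. The steps among compound 2, compound 3 and compound 4 cannot be read, since both ends of each are limits, and these three compounds cannot be ranked.

The compounds shown leave open whether any group on this phenyl ring gives a number clearly lower than that of compound 1. On these data alone, an amine or a carboxylic acid in place of the nitro would be one test of this, and how far compound 2, compound 3 and compound 4 truly lie from one another also stays unknown.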